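The source may report more compounds than this note shows. Statements on the series, on what has been measured and on what is new or still open speak of the compounds shown alone.

Measured so far:
Compound 1, `O=C(CN1CCC(c2ccccc2)(c2ccccc2)C1=O)N1CCN(C(c2ccccc2)c2ccccc2)CC1`, in a physicochemical assay for solubility, at pH 7 (on this read-out lower numbers stand for lower solubility and higher numbers for higher solubility), compound 1 gives < 25000 nM, which is a limit of the assay rather than a number.
Compound 2, `O=C(CN1CCCC(c2ccccc2)(c2ccccc2)C1=O)N1CCN(Cc2cccc(Cl)c2)CC1`, in this assay compound 2 gives < 25000 nM, again a limit and not a number.

Both values therefore sit at the same limit, and nothing separates them: the limit of < 25000 nM in this assay, at which 2 of the 2 values shown sit. Compound 2 thus stands only at a limit, with no measured number of its own.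

Compound 3, `O=C(CN1CCCC(c2ccccc2)(c2ccccc2)C1=O)N1CCN(Cc2ccc(Cl)cc2Cl)CC1`, differs from compound 2 in one place: 2,4-dichlorophenyl in place of 3-chlorophenyl on a saturated chain carbon bound to an amine nitrogen in a ring. Among the compounds with values here, no measured step between two compounds is available here, so the expectation rests on the change alone. With two chlorines in place of one, compound 3 is expected to show a step that the limit leaves unreadable from compound 2 to compound 3, most likely downward or none beyond the scatter, and to remain at or under the limit. Compound 3 is estimated at 10000 nM, within 2000 nM to 25000 nM.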

Compound 3, solubility: < 25000 nM
Compound 3: no number, only a limit; the forecaster's own chance of this, stated with the estimate: 85%; the middle value lies beyond the limit too.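

No step can be read from compound 2 to compound 3, because both stop at the same limit: the limit of < 25000 nM in this assay, at which 3 of the 3 values shown sit. Left open is the actual solubility of each compound shown, and whether 2,4-dichlorophenyl in place of 3-chlorophenyl changes it at all.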